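Amino Added to the Core of Compound 1

The source may hold more compounds than are shown below. What is called first, only, known or untested is meant among the compounds shown, and "the series" means these compounds.

Measured so far in a functional assay on HCT-116 cells (Homo sapiens), read by MTT assay, with a stated time of 72 h; on this read-out higher numbers stand for weaker inhibition and lower numbers for stronger inhibition:
compound 1 `COc1ncnc2c1c(-c1ccoc1)cn2[C@@H]1O[C@H](CO)[C@@H](O)[C@H]1O` gives 110 nM.
compound 2 `CN(C)c1ncnc2c1c(-c1ccoc1)cn2[C@@H]1O[C@H](CO)[C@@H](O)[C@H]1O` sits at a limit of this assay, > 20000 nM.

Compound 1 holds the only number shown; the other value is a limit. For the measured compounds named here, the one measured step is an at least 180-fold higher number from compound 1 to compound 2 (2.25 log units; beyond the scatter), with compound 2 at the limit of > 20000 nM in this assay, at which 1 of the 2 values shown sits.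

Compound 3 `COc1nc(N)nc2c1c(-c1ccoc1)cn2[C@@H]1O[C@H](CO)[C@@H](O)[C@H]1O` differs from compound 1 by amino in place of hydrogen on an aromatic carbon. Going by the values given here, the methoxy group stays in place, so the measured step, which swaps that group, does not bear on this change; no measured step does. With nothing pointing either way, no step beyond the scatter is expected, and compound 3 is estimated at 120 nM (range 30 nM to 500 nM), meaning a 1.1-fold higher number from compound 1 to compound 3 (0.04 log units; within the scatter) as the expected step.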

Compound 3, half-maximal inhibitory concentration: > 20000 nM
Compound 3 was reported as a limit; the forecaster's own chance of this, stated with the estimate: 10%; middle value at least 160-fold (2.22 log units) from the limit.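

The position between two ring nitrogen atoms, which compound 1 and compound 2 left as hydrogen, is not a free place on the core: amino there gives an at least 180-fold higher number from compound 1 to compound 3 (2.25 log units; beyond the scatter). The value of compound 3 is a limit and not a number, so this step gives only a minimum size. Both single changes shown from compound 1, one at the methoxy group and one at this position, end at the same limit: the limit of > 20000 nM in this assay, at which 2 of the 3 values shown sit.

Going by these compounds, whether this outcome belongs to amino alone or to any group at this position stays open. A methyl group or a chlorine atom there would tell the two apart.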